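A few compounds are considered here, and "the series" means these few. Any claim that something is new, unique, unknown or untested is made for them only; others in the source may bear on it.

Measured so far

Compound 1 `CC1CCN(C2CCN(S(=O)(=O)c3nccn3C)CC2)CC1` — > 10000 nM
Compound 2 `Cc1cc(C)c(S(=O)(=O)N2CCC(N3CCN(C)CC3)CC2)c(C)c1` — > 5000 nM

The read-out throughout is an ADME assay on HCT-116 cells (Homo sapiens) for cytotoxicity, read by CellTiter-Glo, with a stated time of 72 h; on this read-out lower numbers stand for stronger inhibition and higher numbers for weaker inhibition. Compound 1 is known only through a limit: in this assay compound 1 gives > 10000 nM, which is a limit of the assay and not a number (the limit of > 10000 nM in this assay, at which 1 of the 2 values shown sits). Compound 2 is likewise known only through a limit, giving > 5000 nM in this assay (the limit of > 5000 nM in this assay, at which 1 of the 2 values shown sits). Among the measured compounds shown here, neither value shows a direction relative to the other; both sit at the edge of what the assay resolves, so the series has no steps between measured compounds and nothing to set the size of a change against.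

The next compound, compound 3 `CC1CCN(C2CCN(S(=O)(=O)c3ccc(Cl)cc3Cl)CC2)CC1`, differs from compound 1 in one place: 2,4-dichlorophenyl in place of 1-methyl-1H-imidazol-2-yl on a sulfonyl sulfur. For the measured compounds named here, with no measured step to lean on, no change beyond the scatter is expected from this exchange in this assay, and the result for compound 3 is expected most likely to be a limit again. The step from compound 1 to compound 3 in this assay is estimated at a step that the limit leaves unreadable from compound 1 to compound 3. For compound 3 the expected value in this assay is 15000 nM, with a range from 4000 nM to 50000 nM.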

Compound 3, half-maximal inhibitory concentration: > 5000 nM
Compound 3 was reported as a limit; the forecaster's own chance of this, stated with the estimate: 70%; the middle value is on the limit's open side.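

The step from compound 1 to compound 3 cannot be read: in this assay each of the two is known only through a limit. The compounds shown leave open whether 2,4-dichlorophenyl in place of 1-methyl-1H-imidazol-2-yl on a sulfonyl sulfur changes the result in this assay at all, and in which direction.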